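From benzyloxy to pyridin-2-yl: what clearance to expect

The compounds below may be only part of what the source reports. "The series", "measured", "known", "first", "only" and "open" are said of these compounds alone.

Measured so far in an ADME assay on microsomes (Homo sapiens) for metabolic stability; a higher number here means faster removal of the compound, a lower number slower removal
- compound 1 `CNC(=O)[C@@H]1CCCN1S(=O)(=O)c1ccc(Cl)c(COc2cccc3c(C(F)(F)F)cc(C)nc23)c1Cl` gives 250 mL/min/kg
- compound 2 `CNC(=O)[C@@H]1CCCN1S(=O)(=O)c1ccc(Cl)c(COc2cccc3c(OCc4ccccc4)cc(C)nc23)c1Cl` gives 467 mL/min/kg

Compound 2 has a single measured neighbour, and the gap to it is a 1.9-fold higher number from compound 1 to compound 2 (0.27 log units; within the scatter) so the two cannot be told apart. Compound 3 `CNC(=O)[C@@H]1CCCN1S(=O)(=O)c1ccc(Cl)c(COc2cccc3c(-c4ccccn4)cc(C)nc23)c1Cl` differs from compound 2 in one place, pyridin-2-yl in place of benzyloxy on an aromatic carbon with pyridin-2-yl in place of benzyloxy on an aromatic carbon. Among the compounds with values here, the one measured step at this carbon, between compound 1 and compound 2, stayed within the scatter, and no compound with pyridin-2-yl has been measured. In this assay no change beyond the scatter is therefore expected, and the direction is uncertain. The expected step is a 1.5-fold lower number from compound 2 to compound 3 (0.16 log units; within the scatter) and no more than a lean toward the middle of the two values. Compound 3 is estimated at 320 mL/min/kg with an expected range from 150 mL/min/kg to 650 mL/min/kg for repeated measurements.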

Compound 3, clearance: 183 mL/min/kg
Beside the measured number, compound 3's estimate is 1.7-fold (0.24 log units) above it; the measured number falls inside the stated range.
By their numbers in this assay, from the lowest: compounds 3, 1 and 2 (each within the scatter of the next, the first and the last beyond it).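

Within the data shown here, this carbon, opposite the ring nitrogen, now shows a step beyond the scatter in this assay: pyridin-2-yl in place of benzyloxy gives a 2.6-fold lower number from compound 2 to compound 3 (0.41 log units; beyond the scatter) as the first such change at this position. Pyridin-2-yl in place of trifluoromethyl gives a 1.4-fold lower number from compound 1 to compound 3 (0.14 log units; within the scatter) and so leaves those two groups indistinguishable here. Nothing available explains either step. Going by these compounds, whether a plain phenyl ring, an amine or a carboxylic acid at this carbon would give a number closer to compound 2 or to compound 3 remains open.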